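The source may hold more compounds than are shown below. What is called first, only, known or untested is meant among the compounds shown, and "the series" means these compounds.

Compound 1, `CCCOC1(c2ccc(Br)cc2)SC=C(C)n2c1noc2=O`, is a bromophenyl-bearing member of this series, and in a functional assay (Cavia porcellus) with Rattus norvegicus as the target (a lower number here means that less compound is needed, a higher number that more compound is needed for the effect), compound 1 gives 410 nM. Compound 2, `CCCCCCOC1(c2ccc(Br)cc2)SC=C(C)n2c1noc2=O`, carries a longer chain on the oxygen, and in this assay compound 2 gives 830 nM. The change between them is propyl in place of hydrogen on a saturated chain carbon, three bonds along the chain from an oxygen on a saturated carbon, and it brought a 2.0-fold higher number from compound 1 to compound 2 (0.31 log units; beyond the scatter).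

Compound 3, `CCCCCCCCCO[C@@]1(c2ccc(Br)cc2)SC=C(C)n2c1noc2=O`, differs from compound 1 in a way that is not broken down here. In this assay compound 3 gives 350 nM, which lies within the usual scatter of the number for compound 1, so no order between the two can be claimed; against compound 2 the number for compound 3 is lower, and that gap is larger than the scatter.

Compound 4, `CCCCCCCCCCCCO[C@@]1(c2ccc(Br)cc2)SC=C(C)n2c1noc2=O`, has not yet been measured. It differs from compound 3 by propyl in place of hydrogen on a saturated chain carbon, nine bonds along the chain from an oxygen on a saturated carbon. This is the same kind of change as that from compound 1 to compound 2, but it sits further out: three bonds along the chain from the oxygen in the earlier pair, nine bonds along the chain from the oxygen here. For the measured compounds named here, the only precedent, the step from compound 1 to compound 2 with a 2.0-fold higher number from compound 1 to compound 2 (0.31 log units; beyond the scatter), was a modest rise; on that footing a similar modest rise is expected, a 1.7-fold higher number from compound 3 to compound 4 (0.23 log units; within the scatter). Compound 4 is therefore estimated at 600 nM in this assay, with a likely span from 250 nM to 1500 nM.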

Compound 4, half-maximal effective concentration: 130 nM
Compound 4: middle estimate off by 4.6-fold (0.66 log units), on the high side, and the stated range ends above it.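

In this assay, the change of propyl in place of hydrogen did not keep its direction when it was carried to a second core: it now gives a 2.7-fold lower number from compound 3 to compound 4 (0.43 log units; beyond the scatter), and the earlier step on the core of compound 1 ran the other way: the same change on two cores in this assay, a 2.0-fold higher number (0.31 log units; beyond the scatter) from compound 1 to compound 2 and a 2.7-fold lower number (0.43 log units; beyond the scatter) from compound 3 to compound 4, 5.5-fold (0.74 log units) apart, beyond the scatter of two such steps

The step seen on one member of this series therefore gave no safe guide to the same change on another, neither in size nor in direction. What the two steps do not show is what sets them apart, since the starting compound and the place of the change differ together, three bonds along the chain from the oxygen in one pair and nine bonds along the chain in the other, and two steps cannot separate these or establish a trend with chain length.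

The compounds shown leave open how a chain longer than that of compound 4 would read in this assay, and whether the number would stay on the low side or turn upward again. They also leave open how a chain carrying an amine or a carboxylic acid would read on the oxygen of the shared core.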